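This account rests on a few compounds, and the source may have more. Where it says the series, first, only, none or still open, it means among the compounds named here.

Measured so far in a functional assay on DU-145 cells (Homo sapiens) for inhibition, read by MTT assay, with a stated time of 24 h; on this read-out lower numbers stand for stronger inhibition and higher numbers for weaker inhibition:
compound 1 `CCOC(=O)C1=Cc2ccccc2OC1(OCc1cn(-c2ccc(F)cc2)nn1)C(F)(F)F` gives 8900 nM.
compound 2 `CCOC(=O)C1=Cc2ccccc2OC1(OCc1cc(-c2ccc(OC)cc2)no1)C(F)(F)F` gives > 150000 nM, which is a limit of the assay and not a number.
compound 3 `CCOC(=O)C1=Cc2ccccc2OC1(OCc1cc(-c2ccc(Br)cc2)no1)C(F)(F)F` gives 71700 nM.

Among the two numbers in this assay, compound 3 stands highest; compound 1 sits well below it, and for compound 2 only the limit of > 150000 nM in this assay, at which 1 of the 3 values shown sits, is known. Compound 4 `CCOC(=O)C1=Cc2ccccc2OC1(OCc1cc(-c2ccc3ccccc3c2)no1)C(F)(F)F` differs from compound 3 by naphthalen-2-yl in place of 4-bromophenyl on an aromatic carbon. Among the measured compounds shown here, the only measured step at this position is an at least 2.0-fold lower number from compound 2 to compound 3 (0.32 log units; beyond the scatter), which exchanged a substituent on the phenyl rather than the phenyl itself, so it bears only loosely on the present change. A modest step is therefore expected in this assay, more likely toward a lower number, but not clearly beyond the scatter. Compound 4 is estimated at 45000 nM, between 12000 nM and 150000 nM, an expected step of a 1.6-fold lower number from compound 3 to compound 4 (0.20 log units; within the scatter).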

Compound 4, half-maximal inhibitory concentration: 71800 nM
For compound 4 the middle estimate is 1.6-fold (0.20 log units) below the measured one; the range from low to high includes it.
By their numbers in this assay, from the lowest: compound 1; then compounds 3 and 4 (each within the scatter of the next). At a limit, above all of these: compound 2.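

In this assay, the larger naphthalen-2-yl group in place of 4-bromophenyl on this aromatic carbon gives a 1.0-fold higher number from compound 3 to compound 4 (0.00 log units; within the scatter), so the second six-membered aromatic ring leaves the read-out unchanged. With naphthalen-2-yl in place of 4-methoxyphenyl, the result is an at least 2.0-fold lower number from compound 2 to compound 4 (0.31 log units; beyond the scatter), the same direction as the earlier bromo exchange. The size of that step remains bounded, since compound 2 stands at a limit of the assay and not a number: the limit of > 150000 nM in this assay, at which 1 of the 4 values shown sits.

Going by these compounds, what an amine or a carboxylic acid at this position would do remains open.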